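Shortening the side chain of compound 1 and closing its amine into a ring

A few compounds are considered here, and "the series" means these few. Any claim that something is new, unique, unknown or untested is made for them only; others in the source may bear on it.

Compound 1 `CN(C)CCCCCn1c2c(c3ccccc31)C(=O)c1c[n+]([O-])c3ccccc3c1C2=O` is the compound with the lowest number among the two measured here: in a toxicity assay on L02 cells (Homo sapiens) for cytotoxicity, read by MTT assay, with a stated time of 72 h (a lower number here means a stronger inhibitor, a higher number a weaker inhibitor), compound 1 gives 240 nM, whereas compound 2 `CN1CCN(CCCCCCn2c3c(c4ccccc42)C(=O)c2c[n+]([O-])c4ccccc4c2C3=O)CC1` gives 3800 nM. Compound 3 `O=C1c2c[n+]([O-])c3ccccc3c2C(=O)c2c1c1ccccc1n2CCCN1CCC(O)CC1` has not yet been measured. Its difference from compound 1 is 4-hydroxypiperidin-1-yl in place of 2-(dimethylamino)ethyl on a saturated chain carbon, three bonds along the chain from an aromatic nitrogen. Going by the values given here, only one measured step bears on this change, the one that also replaces the dimethylamino end with a cyclic amine, a 16-fold higher number from compound 1 to compound 2 (1.20 log units; beyond the scatter), a large loss. A smaller but still clear weakening is therefore expected in this assay, a 5.0-fold higher number from compound 1 to compound 3 (0.70 log units; beyond the scatter). Compound 3 is estimated at 1200 nM, within a range of 400 nM to 4000 nM.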

Compound 3, half-maximal inhibitory concentration: 120 nM
The estimate for compound 3 lay 10-fold (1.00 log units) above the measured number, outside the stated range (below it).
By their numbers in this assay, from the lowest: compounds 3 and 1 (each within the scatter of the next); then compound 2.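

In this assay the step to the 4-hydroxypiperidin-1-yl end is a 2.0-fold lower number from compound 1 to compound 3 (0.30 log units; within the scatter) so a ring-closed amine on this chain need not bring the large loss seen for compound 2. The step of a 32-fold lower number from compound 2 to compound 3 (1.50 log units; beyond the scatter) shows that cyclic amines at this position can differ widely. No measurement shown here accounts for these results.

Going by these compounds, compound 2 and compound 3 differ in both chain length and terminal amine, so the share of each remains open. A plain piperidine or a morpholine on the same chain would test the role of the hydroxyl-bearing ring.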